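Swapping Ethyl for Phenyl on a Sulfonyl Chain

The source may hold more compounds than are shown below. What is called first, only, known or untested is meant among the compounds shown, and "the series" means these compounds.

In a functional assay on Huh-7 cells (Homo sapiens) for cytotoxicity, read by MTT assay, with a stated time of 72 h (on this read-out higher numbers stand for lower toxicity in this test and lower numbers for higher toxicity in this test), compound 1 (`CCCS(=O)(=O)N1CCC2(CC1)OOC1(CCCCC1)OO2`) gives > 100 ug/mL as a limit and not as a number. Compound 2 (`CCCS(=O)(=O)N1CCC2(CC1)OOC1(CCCCCC1)OO2`) gives > 100 ug/mL as a limit too. Compound 3 (`O=S(=O)(CCCCl)N1CCC2(CC1)OOC1(CCCC1)OO2`) gives > 100 ug/mL as a limit as well. Compound 1 thus stands with the other two at one shared ceiling (the limit of > 100 ug/mL in this assay, at which 3 of the 3 values shown sit) and no true value is known for any of them.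

Compound 4 (`O=S(=O)(Cc1ccccc1)N1CCC2(CC1)OOC1(CCCCC1)OO2`) has not yet been tested. It keeps the core of compound 1 and carries one change (phenyl in place of ethyl on a saturated chain carbon bound to a sulfonyl sulfur) in which phenyl takes the place of ethyl on a saturated chain carbon bound to a sulfonyl sulfur, so that propyl becomes benzyl.

No measured step among these compounds shows what such a change does. In this assay no shift beyond the usual scatter is expected for the new group, with compound 1 and its limit of > 100 ug/mL as the only anchor. The estimated step (a number no higher from compound 1 to compound 4 (the limit leaves the size open)) is therefore small, and any surprise would more likely lie toward greater toxicity. Compound 4 is expected in this assay at 100 ug/mL with a range from 40 ug/mL to 200 ug/mL as the estimate.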

Compound 4, half-maximal cytotoxic concentration: > 100 ug/mL
Compound 4 ended at the assay's limit; the forecaster's own chance of this, stated with the estimate: 65%; the middle value sits exactly at the limit.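

Compound 1 and compound 4 both end at a limit and not at a number, so no step from one to the other can be read in this assay: the limit of > 100 ug/mL in this assay, at which 4 of the 4 values shown sit.

The compounds shown leave open how much the change from propyl to benzyl shifts the true value, and at what concentration any of the four becomes toxic to these cells.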